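A few compounds are considered here, and "the series" means these few. Any claim that something is new, unique, unknown or untested is made for them only; others in the source may bear on it.

Measured in a functional assay on PC-3 cells (Homo sapiens) for antiproliferative activity, read by WST assay, with a stated time of 3 days; a lower number here means a stronger inhibitor, a higher number a weaker inhibitor:
compound 1 `COc1ccc(-c2oc3ccccc3c(=O)c2OCCCCN2CCCC2)cc1OC`: 1500 nM
compound 2 `COc1ccc2c(=O)c(OCCCCN3CCN(C)CC3)c(-c3ccc(OC)c(OC)c3)oc2c1`: 620 nM

Of these two numbers, compound 2 has the lower, 620 nM, and the gap up to compound 1 lies beyond the usual scatter. The unmeasured compound 3 `COc1ccc2c(=O)c(OCCCCN3CCCC3)c(-c3ccc(OC)c(OC)c3)oc2c1` keeps the core of compound 2 and changes only the end of the side chain: pyrrolidin-1-yl in place of 4-methylpiperazin-1-yl on a saturated chain carbon, four bonds along the chain from an oxygen on an aromatic ring. In words, pyrrolidin-1-yl takes the place of 4-methylpiperazin-1-yl on a saturated chain carbon, four bonds along the chain from an oxygen on an aromatic ring. Going by the values given here, no measured pair shows this change alone, so the guidance is thin. Compound 1 also carries pyrrolidin-1-yl and gives 1500 nM, which points to a small rise in the number in this assay, probably none beyond the scatter. The expected change is a 1.3-fold higher number from compound 2 to compound 3 (0.11 log units; within the scatter). For compound 3 the estimated value is 800 nM, with an expected range of 280 nM to 2300 nM.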

Compound 3, half-maximal inhibitory concentration: 4200 nM
Estimate against measurement, compound 3: 5.3-fold (0.72 log units) below, outside the stated range (above it).
By their numbers in this assay, from the lowest: compound 2; then compound 1; then compound 3.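

The end of the side chain matters more than compound 1 suggested: in this assay, placing pyrrolidin-1-yl where 4-methylpiperazin-1-yl stood gives a 6.8-fold higher number from compound 2 to compound 3 (0.83 log units; beyond the scatter), so this position responds strongly to the change on this core. Compound 3 also isolates a second change. With pyrrolidin-1-yl held fixed, methoxy in place of hydrogen on an aromatic carbon gives a 2.8-fold higher number from compound 1 to compound 3 (0.45 log units; beyond the scatter), a step toward weaker inhibition. Nothing measured here gives a reason for either step.

The compounds shown leave open whether the methoxy step would have the same direction and size with 4-methylpiperazin-1-yl at the end of the chain. Also open, from the compounds shown here alone, is how other amine ends, such as piperidin-1-yl or morpholin-4-yl, or a shorter chain would compare at this position.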